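The source may hold more compounds than are shown below. What is called first, only, known or untested is meant among the compounds shown, and "the series" means these compounds.

Measured in a functional assay on FM3A cells (Mus musculus) for antiproliferative activity, with a stated time of 48 h; a lower number here means a stronger inhibitor, a higher number a weaker inhibitor:
- compound 1 `C=C(Br)C(=O)Nc1ccc(/C=C/C(=O)c2ccc(Br)cc2)cc1`: 1100 nM
- compound 2 `C=C(Br)C(=O)Nc1ccc(/C=C/C(=O)c2ccc(OC)cc2)cc1`: 1200 nM
- compound 3 `Nc1ccc(/C=C/C(=O)c2ccc(Br)cc2)cc1`: 120000 nM

Of these three, compound 3 has the highest number, well beyond the scatter from both others. Compound 4 `COc1ccc(C(=O)/C=C/c2ccc(N)cc2)cc1` differs from it by methoxy in place of bromo on an aromatic carbon. The same exchange has been measured once, as a 1.1-fold higher number from compound 1 to compound 2 (0.04 log units; within the scatter), which lies within the scatter. The much larger a 110-fold higher number from compound 1 to compound 3 (2.04 log units; beyond the scatter) concerns the (1-bromoethenyl)carbonyl on nitrogen, which does not change here. Whether the exchange behaves alike without that group has not been measured. The expected result is therefore no step beyond the scatter, and the estimate is a 1.2-fold lower number from compound 3 to compound 4 (0.08 log units; within the scatter). For compound 4 the estimated value is 100000 nM, with an expected range from 40000 nM to 250000 nM.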

Compound 4, half-maximal inhibitory concentration: 282000 nM
For compound 4 the middle estimate is 2.8-fold (0.45 log units) below the measured one; the whole stated range lies below it.
By their numbers in this assay, from the lowest: compounds 1 and 2 (each within the scatter of the next); then compound 3; then compound 4.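

In this assay, methoxy in place of bromo on an aromatic carbon gives a step beyond the scatter once the (1-bromoethenyl)carbonyl is absent from the nitrogen, with a 2.4-fold higher number from compound 3 to compound 4 (0.37 log units; beyond the scatter). Even so, this step cannot be told apart from the one on the core of compound 1: the same change on two cores in this assay, a 1.1-fold higher number (0.04 log units; within the scatter) from compound 1 to compound 2 and a 2.4-fold higher number (0.37 log units; beyond the scatter) from compound 3 to compound 4, 2.2-fold (0.33 log units) apart, within the scatter of two such steps. Removing the (1-bromoethenyl)carbonyl costs as much with methoxy, a 240-fold higher number from compound 2 to compound 4 (2.37 log units; beyond the scatter), as it does with bromo: the same change on two cores in this assay, a 110-fold higher number (2.04 log units; beyond the scatter) from compound 1 to compound 3 and a 240-fold higher number (2.37 log units; beyond the scatter) from compound 2 to compound 4, 2.2-fold (0.33 log units) apart, within the scatter of two such steps.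

The compounds shown leave open whether a nitrile or a trifluoromethyl at this place would follow bromo and methoxy on either core. They also leave open whether a plain acetyl on the nitrogen would keep any of the (1-bromoethenyl)carbonyl's gain.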